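Adding a Second Methoxy to Compound 2

This account rests on a few compounds, and the source may have more. Where it says the series, first, only, none or still open, it means among the compounds named here.

In an ADME assay on MDBK cells (Bos taurus) for cytotoxicity, read by MTT assay, with a stated time of 96 h (on this read-out higher numbers stand for lower toxicity in this test and lower numbers for higher toxicity in this test), compound 1 `COc1ccc(-c2nc3cc(C(C)=O)ccc3[nH]2)c(OC)c1` gives 73000 nM. Compound 2 `COc1ccc(-c2nc3cc(C(C)O)ccc3[nH]2)cc1` gives > 100000 nM, which is a limit of the assay and not a number. Compound 3 `COc1ccc(-c2nc3cc(C(C)O)ccc3[nH]2)c(OC)c1` differs from compound 2 by a single change, methoxy in place of hydrogen on an aromatic carbon. Among the compounds with values here, no measured pair shows what this change does in this assay. A small move toward lower numbers is expected, since compound 1 gives 73000 nM. The expected step is an at least 1.1-fold lower number from compound 2 to compound 3 (0.07 log units; that floor lies within the scatter). Compound 3 is estimated at 85000 nM, with a range of 45000 nM to 140000 nM.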

Compound 3, half-maximal cytotoxic concentration: > 100000 nM
Compound 3 ended at the assay's limit; the forecaster's own chance of this, stated with the estimate: 50%; middle value at least 1.1-fold (0.07 log units) from the limit.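

In this assay, compound 3, with its added methoxy ortho to a large group and meta to a methoxy group, still stands at a limit of the assay, so this change shows no readable drop at this position. The step for the methoxy itself cannot be read, because both compounds with the 1-hydroxyethyl group sit at that limit: the limit of > 100000 nM in this assay, at which 2 of the 3 values shown sit. With the two methoxy groups kept, 1-hydroxyethyl in place of acetyl gives an at least 1.3-fold higher number from compound 1 to compound 3 (0.13 log units; that floor lies within the scatter).

Still open, as far as these compounds go, is how far past the limit compound 2 and compound 3 lie. Also open, from the compounds shown here alone, is whether an amine or a longer chain such as ethoxy at this position would give a readable number.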